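Oxygen-to-sulfur exchange at the aryl ether linker

The compounds below may be only part of what the source reports. "The series", "measured", "known", "first", "only" and "open" are said of these compounds alone.

Among the measured compounds shown here, in a functional assay on SNB-19 cells (Homo sapiens) for inhibition, read by sulforhodamine B assay, with a stated time of 48 h (on this read-out lower numbers stand for stronger inhibition of growth and higher numbers for weaker inhibition of growth), compound 3 `Nc1cc(N)c2nc(-c3ccccc3)c(Oc3ccc(F)cc3)nc2c1` gives 17400 nM, one of only two numbers. Compound 1 `Nc1cc(N)c2nc(-c3ccccc3)c(Oc3ccc(Cl)c(Cl)c3)nc2c1` gives 20900 nM, and the step of a 1.2-fold lower number from compound 1 to compound 3 (0.08 log units; within the scatter) leaves the two within the scatter of each other. Compound 2 `COc1ccc(Sc2nc3cc(N)cc(N)c3nc2-c2ccccc2)cc1` yields only a limit, < 100000 nM, namely (the limit of < 100000 nM in this assay, at which 1 of the 3 values shown sits). Compound 4 `Nc1cc(N)c2nc(-c3ccccc3)c(Sc3ccc(F)cc3)nc2c1` carries (4-fluorophenyl)sulfanyl in place of 4-fluorophenoxy on an aromatic carbon. Going by these compounds, the two measured steps that touch a sulfanyl linker, a step that the limit leaves unreadable from compound 1 to compound 2 and a step that the limit leaves unreadable from compound 2 to compound 3, have no readable size, so direction and magnitude remain open. The expected step is therefore a 1.4-fold higher number from compound 3 to compound 4 (0.16 log units; within the scatter), set close to no change but with a wide band. Compound 4 is estimated at 25000 nM, between 8000 nM and 90000 nM.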

Compound 4, concentration for 50% growth inhibition: 20000 nM
Estimate against measurement, compound 4: 1.3-fold (0.10 log units) above; low and high end bracket the measured number.
By their numbers in this assay, from the lowest: compounds 3, 4 and 1 (each within the scatter of the next).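

In this assay, the oxygen-to-sulfur exchange now has a readable size with the 4-fluorophenyl group held constant: a 1.1-fold higher number from compound 3 to compound 4 (0.06 log units; within the scatter). The comparison with the 3,4-dichlorophenoxy group gives a 1.0-fold lower number from compound 1 to compound 4 (0.02 log units; within the scatter), so compound 1, compound 3 and compound 4 all lie within the scatter of one another, and neither linker atom nor this ring change separates them. Compound 2 has only a limit, so its step to compound 4 cannot be read: the limit of < 100000 nM in this assay, at which 1 of the 4 values shown sits.

Going by these compounds, whether any group at this position moves the number beyond the scatter stays open. An amine linker in place of the sulfur, or a carboxylic acid on the aryl ring, would test this.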